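Swapping the Amide Aryl Group for Cyclohexyl

The source may hold more compounds than are shown below. What is called first, only, known or untested is meant among the compounds shown, and "the series" means these compounds.

Compound 1 `CCCCCCCCCCn1cc(Cn2nc(N)c3c(C(F)(F)F)cc(-c4ccccc4)nc32)nn1`: in a functional assay on B16-F10 cells (Mus musculus) for cytotoxicity, read by MTT assay, with a stated time of 24 h (on this read-out lower numbers stand for stronger inhibition and higher numbers for weaker inhibition), compound 1 gives 84.9 ug/mL.
Compound 2 `Nc1nn(Cc2cn(-c3ccc(O)c([N+](=O)[O-])c3)nn2)c2nc(-c3ccccc3)cc(C(F)(F)F)c12`: compound 2 gives 42.3 ug/mL.
Compound 3 `Nc1nn(Cc2cn(CC(=O)Nc3ccc(F)cc3Br)nn2)c2nc(-c3ccccc3)cc(C(F)(F)F)c12`: compound 3 gives 98 ug/mL.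

Compound 3 shows the highest number of the three. The step of a 1.2-fold higher number from compound 1 to compound 3 (0.06 log units; within the scatter) stays within the scatter, whereas a 2.3-fold higher number from compound 2 to compound 3 (0.36 log units; beyond the scatter) lies beyond it, though only modestly.

Compound 4 `Nc1nn(Cc2cn(CC(=O)NC3CCCCC3)nn2)c2nc(-c3ccccc3)cc(C(F)(F)F)c12` differs from compound 3 by cyclohexyl in place of 2-bromo-4-fluorophenyl on an amide-type nitrogen. Among the measured compounds shown here, no measured step alters the group on the amide nitrogen; the two steps that reach compound 3 exchange the whole substituent on the aromatic nitrogen, and even those spread the numbers only narrowly. The step of a 1.1-fold lower number from compound 3 to compound 4 (0.04 log units; within the scatter) is therefore expected to stay within the scatter. Compound 4 is estimated at 90 ug/mL, with a range from 45 ug/mL to 180 ug/mL.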

Compound 4, half-maximal inhibitory concentration: 99.1 ug/mL
Estimate against measurement, compound 4: 1.1-fold (0.04 log units) below; the range from low to high includes it.
By their numbers in this assay, from the lowest: compounds 2, 1, 3 and 4 (each within the scatter of the next, the first and the last beyond it).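

On the amide-type nitrogen, in this assay, cyclohexyl in place of 2-bromo-4-fluorophenyl gives a 1.0-fold higher number from compound 3 to compound 4 (0.00 log units; within the scatter) and so shows no difference between the aromatic and the non-aromatic ring at this position. Compound 4 stands to the other two much as compound 3 does, with a 1.2-fold higher number from compound 1 to compound 4 (0.07 log units; within the scatter) inside the scatter and a 2.3-fold higher number from compound 2 to compound 4 (0.37 log units; beyond the scatter) beyond it, though modestly. Nothing given here accounts for this result.

The compounds shown leave open whether a small methyl group or a free amine on the amide-type nitrogen would separate from these values. They also leave open whether a carboxylic acid in place of the whole amide would do so.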